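Sulfonamide to pyrazole swap: lipophilicity working notes

The compounds below may be only part of what the source reports. "The series", "measured", "known", "first", "only" and "open" are said of these compounds alone.

Measured so far:
- compound 1, `CNS(=O)(=O)c1ccc(-c2cnc(N)c(-c3ccc(OC)nc3)c2)cc1`, in a physicochemical assay for lipophilicity, at pH 7.4 (a lower number here means a more polar compound, a higher number a more lipophilic compound), gives 2.2
- compound 2, `COc1ccc(-c2cc(-c3ccc(NS(C)(=O)=O)cc3)cnc2N)cn1`, in this assay gives 2.2

Going by the values given here, compound 2 sits level with compound 1 at the digits printed; the only measured step, no change at the digits printed from compound 1 to compound 2 (within the scatter), is within the scatter, so the pair gives no direction for this series so far.

The next compound is compound 3, `COc1ccc(-c2cc(-c3ccc(-n4cccn4)cc3)cnc2N)cn1`, not yet measured in this assay. It differs from compound 2 in one place: 1H-pyrazol-1-yl in place of methanesulfonamido on an aromatic carbon.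

Among the compounds with values here, no measured step covers a pyrazole entering in place of a sulfonamide. Within the data shown here, the one step available, no change at the digits printed from compound 1 to compound 2 (within the scatter), exchanges two sulfur-bearing groups of the same atom count and says nothing about this replacement, so the expectation rests on the counted difference alone: one hydrogen-bond donor, two oxygen atoms and one sulfur leave, and a five-membered aromatic ring enters. An upward step is expected for compound 3, a number 0.90 log units higher from compound 2 to compound 3 (beyond the scatter), with wide uncertainty. Compound 3 is therefore estimated at 3.1 in this assay, expected to fall between 2.5 and 3.7.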

Compound 3, distribution coefficient: 3.1
Compound 3: the middle estimate sits on the measured number at the digits printed; measured number inside the range.
By their numbers in this assay, from the lowest: compounds 1 and 2 (each within the scatter of the next); then compound 3.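

In this assay, going by these compounds alone, 1H-pyrazol-1-yl in place of methanesulfonamido, on an aromatic carbon para to a large group, gives a number 0.90 log units higher from compound 2 to compound 3 (beyond the scatter) and provides the first step beyond the scatter. The same group in place of methylsulfamoyl gives a number 0.90 log units higher from compound 1 to compound 3 (beyond the scatter) as its reading, whereas exchanging the two sulfur-bearing groups gave no change at the digits printed from compound 1 to compound 2 (within the scatter) and so showed no sensitivity to the group at this position; the new compound shows that this position can move the number. Nothing available separates the departure of the hydrogen-bond donor and the sulfur-bearing group from the entry of the five-membered aromatic ring, and no supporting data bear on why the number moved.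

The compounds shown hold only one ring at this position, so they leave open whether a different five-membered aromatic ring such as imidazole would give a number near that of compound 3. On these data alone, it also remains open where an amine or a carboxylic acid on the same aromatic carbon would fall in this assay relative to compound 2 and compound 3.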